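Trading a Chloroaryl Amide for a Dimethylaminopropyl Chain

A few compounds are considered here, and "the series" means these few. Any claim that something is new, unique, unknown or untested is made for them only; others in the source may bear on it.

Of the compounds shown here, two that share one core have been measured in a functional assay on A549 cells (Homo sapiens) for inhibition, read by MTT assay, with a stated time of 72 h; on this read-out higher numbers stand for weaker inhibition and lower numbers for stronger inhibition. Compound 1 `O=C(CCC(=O)OCCCCCCSc1ccc([N+](=O)[O-])c2nonc12)Nc1ccccc1Cl` gives 2750 nM, and compound 2 `O=C(CCC(=O)OCCCCCCSc1ccc([N+](=O)[O-])c2nonc12)Nc1ccc(F)cc1` gives 6300 nM. Among these two numbers compound 1 stands lowest; the only step recorded, a 2.3-fold higher number from compound 1 to compound 2 (0.36 log units; beyond the scatter), exchanges one aryl group for another on the amide-type nitrogen.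

Compound 3 `CN(C)CCCNC(=O)CCC(=O)OCCCCCCSc1ccc([N+](=O)[O-])c2nonc12` has not yet been measured in this assay. Relative to compound 1 it carries 3-(dimethylamino)propyl in place of 2-chlorophenyl on an amide-type nitrogen. Going by the values given here, the one measured step bears on it only loosely, since it changes the substituent on the same nitrogen but keeps a ring, whereas here the ring is replaced by a chain. With so little to go on, compound 3 is expected to return a somewhat higher number, roughly a 2.2-fold higher number from compound 1 to compound 3 (0.34 log units; beyond the scatter). Compound 3 is therefore estimated at about 6000 nM, within a range of 1500 nM to 25000 nM.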

Compound 3, half-maximal inhibitory concentration: 1580 nM
Estimate against measurement, compound 3: 3.8-fold (0.58 log units) above, within the range that was stated.
By their numbers in this assay, from the lowest: compounds 3 and 1 (each within the scatter of the next); then compound 2.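

The amide-type nitrogen does not depend on an aromatic ring in this series: 3-(dimethylamino)propyl in place of 2-chlorophenyl gives a 1.7-fold lower number from compound 1 to compound 3 (0.24 log units; within the scatter) and so leaves the two groups indistinguishable here. Set against the other aryl group, the same chain gives a 4.0-fold lower number from compound 2 to compound 3 (0.60 log units; beyond the scatter) and thus places compound 2 apart from compound 3 by more than the scatter. No measurement at hand speaks to what lies behind these numbers.

As far as these compounds go, it remains open whether the chain's length or its dimethylamino end matters, which a shorter chain, a primary amine or a terminal carboxylic acid on the same nitrogen would help to separate. Also open, from the compounds shown here alone, is how the halogens on the two aryl groups contribute, a question that an unsubstituted phenyl would begin to settle.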